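A few compounds are considered here, and "the series" means these few. Any claim that something is new, unique, unknown or untested is made for them only; others in the source may bear on it.

Two compounds with the same core differ only in the fluorinated phenyl group on an oxygen on a saturated carbon. In a functional assay on Jurkat cells (Homo sapiens) (a lower number here means a stronger inhibitor, a higher number a weaker inhibitor), compound 1 `CC(C)[C@H](NC(=O)COc1cccc2ccccc12)C(=O)N[C@@H](CC(=O)O)C(=O)COc1ccc(F)c(F)c1` gives > 100000 nM, which is a limit of the assay and not a number. Compound 2 `CC(C)[C@H](NC(=O)COc1cccc2ccccc12)C(=O)N[C@@H](CC(=O)O)C(=O)COc1cc(F)cc(F)c1` gives > 100000 nM, which is also a limit. Compound 2 therefore stands at the limit of > 100000 nM in this assay, at which 2 of the 2 values shown sit, with no actual number to place it.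

The next compound, compound 3 `CC(C)[C@H](NC(=O)COc1cccc2ccccc12)C(=O)N[C@@H](CC(=O)O)C(=O)COc1c(F)ccc(F)c1F`, carries 2,3,6-trifluorophenyl in place of 3,5-difluorophenyl in that same place: 2,3,6-trifluorophenyl in place of 3,5-difluorophenyl on an oxygen on a saturated carbon. Going by the values given here, the only measured step that bears on this change is a step that the two limits leave unreadable from compound 1 to compound 2, which also swaps one fluorine pattern for another, and it offers no size to carry over. Compound 2 sits at a limit, so any readable step in this assay could only run toward stronger inhibition, and remaining at the limit is almost as likely. The expected move, held with wide uncertainty, is an at least 5.0-fold lower number from compound 2 to compound 3 (0.69 log units; beyond the scatter). For compound 3 the estimated value is 20000 nM, with an expected range from 1000 nM to 100000 nM.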

Compound 3, half-maximal inhibitory concentration: 1200 nM
Compound 3: middle estimate off by 17-fold (1.22 log units), on the high side; the measured number falls inside the stated range.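

In this assay, the 2,3,6-trifluorophenyl group gives an at least 83-fold lower number from compound 2 to compound 3 (1.92 log units; beyond the scatter), and measured against the 3,4-difluorophenyl group it gives an at least 83-fold lower number from compound 1 to compound 3 (1.92 log units; beyond the scatter). The step between the two difluorophenyl compounds cannot be read, so only now does it become clear that the group on this oxygen can separate a compound with a measurable inhibitory concentration from ones that stay out of range, even with the shared core unchanged. Both readable steps start from a limit rather than a number, so their true sizes are not fixed: the limit of > 100000 nM in this assay, at which 2 of the 3 values shown sit.

The change from the difluorophenyl groups to 2,3,6-trifluorophenyl adds a fluorine and rearranges the others at the same time, so the compounds shown cannot say whether the extra fluorine or the new pattern accounts for the gain. As far as these compounds go, how a plain phenyl group or a pentafluorophenyl group would read in this place also remains open.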